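This account rests on a few compounds, and the source may have more. Where it says the series, first, only, none or still open, it means among the compounds named here.

Working notes on the series. The shared core carries a changing aryl group on a carbon with a double bond to nitrogen. Compound 1 `C[C@H]1CC[C@@H]2[C@@H](OC(=O)[C@]23CC(c2ccc(Cl)cc2)=NO3)[C@]2(C)C(=O)C=C[C@@]12O` bears 4-chlorophenyl, compound 2 `C[C@H]1CC[C@@H]2[C@@H](OC(=O)[C@]23CC(c2ccccc2[N+](=O)[O-])=NO3)[C@]2(C)C(=O)C=C[C@@]12O` bears 2-nitrophenyl, and compound 3 `C[C@H]1CC[C@@H]2[C@@H](OC(=O)[C@]23CC(c2ccc(F)cc2)=NO3)[C@]2(C)C(=O)C=C[C@@]12O` bears 4-fluorophenyl and is not yet measured.

In a physicochemical assay for lipophilicity (a higher number here means a more lipophilic compound, a lower number a more polar compound), compound 1 gives 2.09. In this assay, among the measured compounds shown here, compound 2 gives 1.37, the lowest of the two numbers so far; its nearest neighbour is compound 1, and the single measured step, a number 0.72 log units lower from compound 1 to compound 2 (beyond the scatter), lies beyond the scatter.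

The change now followed is 4-fluorophenyl in place of 2-nitrophenyl on a carbon with a double bond to nitrogen. For the measured compounds named here, it undoes the one measured change in kind: the 2-nitrophenyl that entered from compound 1 leaves again and a 4-fluorophenyl returns. Going by the values given here, that step bears directly here, a number 0.72 log units lower from compound 1 to compound 2 (beyond the scatter), and it is the only guide; no direct comparison of 4-fluorophenyl with 4-chlorophenyl exists in the set. An increase beyond the scatter is expected, a number 0.48 log units higher from compound 2 to compound 3 (beyond the scatter), kept somewhat smaller than the measured step because compound 1 gave 2.09 and compound 3 is not expected to pass it. Compound 3 is therefore estimated at 1.85, with a range from 1.45 to 2.25.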

Compound 3, partition coefficient: 1.58
Estimate against measurement, compound 3: 0.27 log units above; measured number inside the range.
By their numbers in this assay, from the lowest: compounds 2 and 3 (each within the scatter of the next); then compound 1.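

In this assay, 4-fluorophenyl in place of 2-nitrophenyl on the carbon with a double bond to nitrogen gives a number 0.21 log units higher from compound 2 to compound 3 (within the scatter), so these two groups, which differ in heavy atoms and hydrogen-bond acceptors, cannot be told apart at this position. The separation seen earlier therefore does not belong to 2-nitrophenyl alone: fluoro in place of chloro on an aromatic carbon gives a number 0.51 log units lower from compound 1 to compound 3 (beyond the scatter), and among the three compounds, 4-chlorophenyl is the group that stands apart from the other two. The data available here offer nothing that accounts for this result.

The compounds shown leave open whether the separation of compound 1 follows the chloro substituent itself or is particular to the 4-chlorophenyl group, a question that 4-bromophenyl, 2-chlorophenyl or unsubstituted phenyl at the same carbon would address. They also leave open how far the range at this position extends, since every group so far is a substituted phenyl and none carries an amine or a carboxylic acid.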